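Trimethoxyphenyl for Methoxyphenyl: One Step Tried Twice

The source may hold more compounds than are shown below. What is called first, only, known or untested is meant among the compounds shown, and "the series" means these compounds.

Measured in a functional assay on the whole organism (strain Swiss albino) with Mus musculus as the target, in the forced swim test, with a stated time of 5 min, at a dose of 0.5 mg/kg by the intraperitoneal route; on this read-out higher numbers stand for more inhibition at the one dose given (going by the name of the read-out) and lower numbers for less inhibition:
Compound 1, `COc1ccc(-c2cc3cc(C4C(C#N)=C(N)OC5=C4C(=O)CC(C)(C)C5)cc(C(C)C)c3oc2=O)cc1`, gives 64.9%.
Compound 2, `COc1cc(-c2cc3cc(C4C(C#N)=C(N)OC5=C4C(=O)CC(C)(C)C5)cc(C(C)C)c3oc2=O)cc(OC)c1OC`, gives 29.2%.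
Compound 3, `CCC(C)c1cc(C2C(C#N)=C(N)OC3=C2C(=O)CCC3)cc2cc(-c3ccc(OC)cc3)c(=O)oc12`, gives 35.1%.

Compound 1 and compound 2 differ in one place, (3,4,5-trimethoxyphenyl in place of 4-methoxyphenyl on an aromatic carbon), and in a number 35.7 percentage points lower from compound 1 to compound 2 (beyond the scatter). Compound 3 carries a different core; how the core of compound 3 differs from that of compound 1 is not broken down here. Its value in this assay and that of compound 2 lie within the scatter of each other, while compound 1 stands above both.

Compound 4, `CCC(C)c1cc(C2C(C#N)=C(N)OC3=C2C(=O)CCC3)cc2cc(-c3cc(OC)c(OC)c(OC)c3)c(=O)oc12`, is not yet measured. It differs from compound 3 by 3,4,5-trimethoxyphenyl in place of 4-methoxyphenyl on an aromatic carbon, the same change as from compound 1 to compound 2, made at a place described in the same words. Because the earlier step of a number 35.7 percentage points lower from compound 1 to compound 2 (beyond the scatter) was large and compound 3 already starts low at 35.1%, a drop of the same size cannot fully repeat, so a smaller step, a number 20.1 percentage points lower from compound 3 to compound 4 (beyond the scatter), is expected. Compound 4 is therefore estimated at 15%, with a range from 2% to 32%.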

Compound 4, a percentage reported as inhibition, in the whole organism at one dose (the size of the read-out at that dose, not a potency): 56.1%
Compound 4: middle estimate off by 41.1 percentage points, on the low side; measured number outside the range, above it.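

In this assay, the change to 3,4,5-trimethoxyphenyl from 4-methoxyphenyl gave a number 21 percentage points higher from compound 3 to compound 4 (beyond the scatter). Set beside the earlier step on the core of compound 1, this one runs the opposite way, so in these two pairs the outcome of the change depends on the core that carries it: the same change on two cores in this assay, a number 35.7 percentage points lower (beyond the scatter) from compound 1 to compound 2 and a number 21 percentage points higher (beyond the scatter) from compound 3 to compound 4, 56.7 percentage points apart, beyond the scatter of two such steps. This shows that the direction of the step did not carry from one core to the other, but it does not show which part of the cores decides that direction, and two pairs give no rule for any further core in the series.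

At this place on the ring, the compounds shown carry only 4-methoxyphenyl and 3,4,5-trimethoxyphenyl, so it stays open how a phenyl bearing an amine or a carboxylic acid would behave on either core. From the compounds shown here alone, it also stays open whether the reversal would hold at other doses, as each compound is read here at a single dose.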